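Replacing fluoro with methoxy on the weakest of three compounds

The source may hold more compounds than are shown below. What is called first, only, known or untested is meant among the compounds shown, and "the series" means these compounds.

In a functional assay on A549 cells (Homo sapiens) for antiproliferative activity, read by sulforhodamine B assay, with a stated time of 72 h (a higher number here means a weaker inhibitor, a lower number a stronger inhibitor), compound 1 (`CCOc1cc2occ(-c3csc4ccccc34)c(=O)c2c(OCC)c1OC`) gives 2600 nM and compound 2 (`COc1cc2occ(-c3csc4ccccc34)c(=O)c2c(OC)c1OC`) gives 640 nM. Compound 3 (`O=C(/C=C/c1csc2ccccc12)c1cc(F)ccc1O`) has the highest number of the three (7100 nM) and is the weakest, beyond the scatter of both others. Compound 4 (`COc1ccc(O)c(C(=O)/C=C/c2csc3ccccc23)c1`) carries methoxy in place of fluoro on an aromatic carbon, para to a hydroxy group (methoxy in place of fluoro on an aromatic carbon). Among the compounds with values here, no measured pair shows this change, so the expectation starts from compound 3 (7100 nM) and stays close to it. A small estimated step (a 1.4-fold lower number from compound 3 to compound 4 (0.15 log units; within the scatter)) toward a lower number, none beyond the scatter, is expected in this assay for this change. Compound 4 is estimated at 5000 nM with a range from 1600 nM to 15000 nM expected.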

Compound 4, half-maximal inhibitory concentration: 580 nM
The estimate for compound 4 lay 8.6-fold (0.94 log units) above the measured number; the measured number lies below the stated range.
By their numbers in this assay, from the lowest: compounds 4 and 2 (each within the scatter of the next); then compound 1; then compound 3.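

In this assay, methoxy in place of fluoro on an aromatic carbon, para to a hydroxy group, gives a 12-fold lower number from compound 3 to compound 4 (1.09 log units; beyond the scatter), so this position responds strongly to the group it carries, which compound 1 and compound 2 could not show. Within the data shown here, this single pair is the only reading of the change, and no supporting data explain the size of the step. As far as these compounds go, whether an ethoxy group, an amine or a chlorine atom at this position would give a similar step remains open, as does whether the step would persist without the hydroxy group.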